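Methyl for tert-butyl on the urea nitrogen of compound 1

The compounds below may be only part of what the source reports. "The series", "measured", "known", "first", "only" and "open" are said of these compounds alone.

Measured so far:
- compound 1 `CC(C)(C)NC(=O)N1CC1C#N`: 216000 nM
- compound 2 `N#CC1CN1C(=O)Nc1cccc2ccccc12`: 8900 nM

In a functional assay on RPMI-8226 cells (Homo sapiens) for inhibition (on this read-out higher numbers stand for weaker inhibition and lower numbers for stronger inhibition), compound 1 gives 216000 nM, the highest of the two numbers. Compound 2 gives 8900 nM, a lower number and a gap beyond the usual scatter. Compound 3 `CNC(=O)N1CC1C#N` keeps the shared core and changes only one spot: methyl in place of tert-butyl on an amide-type nitrogen. Nothing measured tracks this change directly. A small step toward a higher number, or none beyond the scatter, is expected, so compound 3 is estimated at 300000 nM, between 100000 nM and 1000000 nM, a change of a 1.4-fold higher number from compound 1 to compound 3 (0.14 log units; within the scatter).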

Compound 3, half-maximal inhibitory concentration: 26000 nM
Beside the measured number, compound 3's estimate is 12-fold (1.06 log units) above it, and the stated range ends above it.
By their numbers in this assay, from the lowest: compound 2; then compound 3; then compound 1.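

In this assay, methyl in place of tert-butyl on the amide-type nitrogen gives an 8.3-fold lower number from compound 1 to compound 3 (0.92 log units; beyond the scatter), so inhibition in these cells clearly responds to a change at this position, and removing carbons from this group does not weaken it. This is no simple rule that a smaller group does better, since compound 2 still gives the lowest number of the three, 8900 nM. Nothing available explains why the number falls.

On these data alone, it remains open how an ethyl group or a longer chain at this nitrogen would compare with methyl. As far as these compounds go, a hydroxyl or an amine on such a chain is equally open.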